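The source may report more compounds than this note shows. Statements on the series, on what has been measured and on what is new or still open speak of the compounds shown alone.

Compound 1 `CCC(CC)(c1ccc(OCC(=O)C(C)(C)C)c(C)c1)c1ccc(C(=O)NCC(=O)OC)n1C` gives 23 nM in an assay on HL-60 cells for agonist activity at vitamin D3 receptor (Homo sapiens), with a stated time of 96 h; a higher number here means that more compound is needed for the effect, a lower number that less compound is needed.
Compound 2 `CCn1c(C(=O)NCC(=O)OC)ccc1C(CC)(CC)c1ccc(OCC(=O)C(C)(C)C)c(C)c1` gives 1830 nM in this assay.
Compound 3 `CCC(CC)(c1ccc(OCC(O)C(C)(C)C)c(C)c1)c1ccc(C(=O)NCCCO)n1C` gives 150 nM in this assay.

Compound 3 stands second of the three numbers, beyond the scatter above compound 1 and beyond the scatter below compound 2. Compound 4 `CCC(CC)(c1ccc(OCC(O)C(C)(C)C)c(C)c1)c1ccc(C(=O)N[C@@H](C)CO)n1C` differs from compound 3 in a single place: 1-(hydroxymethyl)ethyl in place of 3-hydroxypropyl on an amide-type nitrogen. Among the compounds with values here, the only measured step, an 80-fold higher number from compound 1 to compound 2 (1.90 log units; beyond the scatter), concerns a methyl placed at the aromatic nitrogen, a different place from the amide nitrogen, so it does not bear on this change. Within the data shown here, no measured pair tests what sits on the amide nitrogen. The expectation for compound 4 is therefore a step no larger than the scatter, no change at the digits printed from compound 3 to compound 4 (within the scatter). Compound 4 is estimated at 150 nM, with a range from 50 nM to 500 nM.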

Compound 4, half-maximal effective concentration: 570 nM
The estimate for compound 4 lay 3.8-fold (0.58 log units) below the measured number; the whole stated range lies below it.
By their numbers in this assay, from the lowest: compound 1; then compound 3; then compound 4; then compound 2.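

What sits on the amide nitrogen matters in this assay: 1-(hydroxymethyl)ethyl in place of 3-hydroxypropyl gives a 3.8-fold higher number from compound 3 to compound 4 (0.58 log units; beyond the scatter), although the two groups hold the same atoms, joined differently. So at this position the arrangement of the chain counts, not just which atoms it contains. No measurement available here explains the step. Still open, going by these compounds, is how the mirror-image form of 1-(hydroxymethyl)ethyl would compare, and how a longer chain, such as 4-hydroxybutyl, or a carboxylic acid on this nitrogen would read.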